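This account rests on a few compounds, and the source may have more. Where it says the series, first, only, none or still open, it means among the compounds named here.

Measured so far in an ADME assay on microsomes from liver (Homo sapiens) for metabolic stability, tested at 2.5 uM; on this read-out higher numbers stand for fast clearance and lower numbers for slow clearance:
- compound 1, `O=S(=O)(c1ccc(F)cc1)c1cnc2cc(F)ccc2c1-c1cccc(F)c1`: 0.95 mL/min
- compound 2, `O=S(=O)(c1cc(Cl)cc(Cl)c1)c1cnc2cc(F)ccc2c1-c1ccccc1F`: 0.93 mL/min
- compound 3, `COc1ccc(S(=O)(=O)c2cnc3cc(F)ccc3c2-c2cccc(F)c2)cc1Cl`: 2.08 mL/min

Compound 3 stands highest of the three numbers in this assay. Going by the values given here, its nearest neighbour is compound 1, and the only single-point step available, a 2.2-fold higher number from compound 1 to compound 3 (0.34 log units; beyond the scatter), runs in the direction of faster clearance and lies beyond the scatter. Among the compounds with values here, compound 2 sits close to compound 1; no single-point step joins compound 2 to either of the others, so those two values are simply noted side by side.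

The next compound, compound 4, `O=S(=O)(c1cc(Cl)cc(Cl)c1)c1cnc2cc(F)ccc2c1-c1cccc(F)c1`, differs from compound 3 in one place: 3,5-dichlorophenyl in place of 3-chloro-4-methoxyphenyl on a sulfonyl sulfur. The step from compound 1 to compound 3 bears on it in reverse, since it swaps the group that entered there back out for a group without the acceptor. Compound 2, which already carries 3,5-dichlorophenyl on a sulfonyl sulfur, gives 0.93 mL/min. Compound 4 is therefore expected to move back down, with a 2.2-fold lower number from compound 3 to compound 4 (0.34 log units; beyond the scatter), landing near compound 1 and compound 2. Compound 4 is estimated at 0.95 mL/min, within 0.5 mL/min to 1.9 mL/min.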

Compound 4, intrinsic clearance in a liver preparation (reported as CLH), per the amount of preparation that the assay uses: 0.41 mL/min
Compound 4: the middle estimate sits 2.3-fold (0.36 log units) above what was measured; measured number outside the range, below it.
By their numbers in this assay, from the lowest: compound 4; then compounds 2 and 1 (each within the scatter of the next); then compound 3.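

In this assay the group on the sulfonyl sulfur proves able to move the number in both directions: a 5.1-fold lower number from compound 3 to compound 4 (0.71 log units; beyond the scatter) is a larger fall than the rise in a 2.2-fold higher number from compound 1 to compound 3 (0.34 log units; beyond the scatter) and it is joined by a 2.3-fold lower number from compound 1 to compound 4 (0.36 log units; beyond the scatter) so that 3,5-dichlorophenyl ends up below both 3-chloro-4-methoxyphenyl and 4-fluorophenyl on this core. The second place also counts, since a 2.3-fold lower number from compound 2 to compound 4 (0.36 log units; beyond the scatter) shows that exchanging 2-fluorophenyl for 3-fluorophenyl on an aromatic carbon changes the number beyond the scatter while the 3,5-dichlorophenyl group stays put. No measurement at hand explains either change.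

On these data alone, whether the sulfonyl order holds with 2-fluorophenyl on the core stays open. So does how a plain phenyl or a 4-methoxyphenyl on the sulfonyl sulfur would compare.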